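This account rests on a few compounds, and the source may have more. Where it says the series, first, only, none or still open, it means among the compounds named here.

Measured so far:
compound 1 `CCN1CCN(c2cc(C)c3cc(NC(=O)c4cccc(C)c4)ccc3n2)CC1`; in a functional assay on MCF7 cells (Homo sapiens) for antiproliferative activity, read by MTT assay, with a stated time of 72 h (a higher number here means a weaker inhibitor, a lower number a stronger inhibitor), compound 1 gives 7800 nM
compound 2 `Cc1cc(NCCN2CCCCC2)nc2ccc(NC(=O)c3ccc(Cl)c(Cl)c3)cc12`; in this assay compound 2 gives 1190 nM

Compound 1 stands at the higher of the two numbers measured, so it is the weaker inhibitor of the pair. Compound 2 sits well apart from it, a gap beyond the scatter. For the measured compounds named here, compound 2 differs from compound 1 in several places at once, so no single-change step is available between the two measured compounds, and their values show only that the series spans a sizeable range.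

The unmeasured member is compound 3 `CCN1CCN(c2cc(C)c3cc(NC(=O)c4ccccc4OC)ccc3n2)CC1`. Relative to compound 1 the change is 2-methoxyphenyl in place of 3-methylphenyl on a carbonyl carbon. The measured pair offers nothing that bears directly on this exchange, so the expected step, a 1.2-fold lower number from compound 1 to compound 3 (0.08 log units; within the scatter), is small, possibly in either direction, and not clearly beyond the scatter. Compound 3 is accordingly estimated at 6500 nM in this assay, with a range from 2000 nM to 20000 nM, to be checked against the measurement.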

Compound 3, half-maximal inhibitory concentration: 13200 nM
Estimate against measurement, compound 3: 2.0-fold (0.31 log units) below; measured number inside the range.
By their numbers in this assay, from the lowest: compound 2; then compounds 1 and 3 (each within the scatter of the next).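

In this assay, for the compounds shown here, the first single-change step is a 1.7-fold higher number from compound 1 to compound 3 (0.23 log units; within the scatter) for 2-methoxyphenyl in place of 3-methylphenyl on a carbonyl carbon whose other neighbour is the amide-type nitrogen. At this position on the core of compound 1, then, the exchange brings in an oxygen and a hydrogen-bond acceptor and moves the methyl-bearing aryl group to a different substitution pattern, yet the two values cannot be told apart, so this single pair gives no sign that the position responds to this change. No measurement available here offers an explanation for this result, and this one pair supports no general rule about the position.

The compounds shown leave open whether a more distinct group on this phenyl ring, such as a carboxylic acid, a dimethylamino group or a nitrile, or a longer chain between the carbonyl and the ring, would give a step beyond the scatter. They also leave open whether the same exchange gives a similar step when the ethylpiperazine of compound 1 is replaced by another amine.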